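This account rests on a few compounds, and the source may have more. Where it says the series, first, only, none or still open, it means among the compounds named here.

Measured in a functional assay on HCT-116 cells (Homo sapiens) for antiproliferative activity, read by MTT assay, with a stated time of 72 h; on this read-out lower numbers stand for stronger inhibition and higher numbers for weaker inhibition:
- Compound 1 `COc1cccc(N2C(=O)COc3ccc(-c4cnc(Cl)c(NS(=O)(=O)c5ccc(F)cc5)c4)cc32)c1`: > 40000 nM
- Compound 2 `O=C1COc2ccc(-c3cnc(Cl)c(NS(=O)(=O)c4ccc(F)cc4)c3)cc2N1C1CCCCC1`: > 40000 nM
- Compound 3 `O=C1COc2ccc(-c3cccc(NS(=O)(=O)c4ccc(F)cc4)c3)cc2N1`: > 40000 nM

Compound 3 gives > 40000 nM, which is a limit of the assay and not a number. It therefore has no exact place in the series, and all three compounds rest on (the limit of > 40000 nM in this assay, at which 3 of the 3 values shown sit).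

Compound 4 `CC(C)N1C(=O)COc2ccc(-c3cccc(NS(=O)(=O)c4ccc(F)cc4)c3)cc21` differs from compound 3 in one place: isopropyl in place of hydrogen on an amide-type nitrogen in a ring. Here, isopropyl stands in place of hydrogen on an amide-type nitrogen in a ring. Going by the values given here, the only measured change on such a nitrogen, cyclohexyl in place of 3-methoxyphenyl, is a step that the two limits leave unreadable from compound 1 to compound 2. The core of compound 1 also differs from that of compound 3. Among the compounds with values here, neither a size nor a direction can be carried over from that step, and no compound so far has left the limit in this assay. Little or no gain is therefore expected, and the result may well be another limit.

The expected change is a number no higher from compound 3 to compound 4 (the limit leaves the size open).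

For compound 4, the estimated value is 40000 nM, with an expected range from 12000 nM to 60000 nM.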

Compound 4, half-maximal inhibitory concentration: 22600 nM
Estimate against measurement, compound 4: 1.8-fold (0.25 log units) above; measured number inside the range.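

In this assay, isopropyl in place of hydrogen on the amide-type nitrogen gives an at least 1.7-fold lower number from compound 3 to compound 4 (0.24 log units; that floor lies within the scatter). As far as these compounds go, the value of compound 3, > 40000 nM, is a limit of the assay and not a number, so the true size of this step stays open. Compound 4 is still the only compound shown that has left that limit, which makes this nitrogen the first place in the series where a change yields an exact number: the limit of > 40000 nM in this assay, at which 3 of the 4 values shown sit.

From the compounds shown here alone, it remains open whether isopropyl matters in particular or whether other groups on this nitrogen, such as methyl, a longer chain like n-butyl, or a chain ending in an amine, would give a lower or higher number. Also open, going by these compounds, is whether isopropyl would have a similar result on the core of compound 1.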